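The source may hold more compounds than are shown below. What is called first, only, known or untested is meant among the compounds shown, and "the series" means these compounds.

For the measured compounds named here, in a functional assay on K562 cells (Homo sapiens) for antiproliferative activity, read by MTT assay, with a stated time of 48 h (a higher number here means a weaker inhibitor, a lower number a stronger inhibitor), compound 1 (`COC(=O)[C@H](C)NC(=O)c1ccc(Oc2nc3ccccc3nc2NC(C)(C)C)cc1`) gives 42200 nM and compound 2 (`CC[C@@H](C)[C@H](NC(=O)c1ccc(Oc2nc3ccccc3nc2NC(C)(C)C)cc1)C(=O)OC`) gives 38700 nM as its reading, so compound 2 stands level with the only other measured compound. Going by the values given here, the single measured step (a 1.1-fold lower number from compound 1 to compound 2 (0.04 log units; within the scatter)) puts sec-butyl in place of methyl on a saturated chain carbon bound to an amide-type nitrogen and a carbonyl carbon. Compound 3 (`C[C@H](NC(=O)c1ccc(Oc2nc3ccccc3nc2NC(C)(C)C)cc1)C(=O)O`) has yet to be measured. It has 1-carboxyethyl in place of 1-(methoxycarbonyl)-2-methylbutyl on an amide-type nitrogen. The side-chain part of this change runs opposite to the measured step, which stayed within the scatter, so little is expected from that part. Among the compounds with values here, no measured compound carries a carboxy group, and the data therefore give no guide to the rest of the change. A moderate rise in the number is tentatively expected, and the estimated change is a 1.6-fold higher number from compound 2 to compound 3 (0.19 log units; within the scatter) on that loose footing. In this assay the estimate for compound 3 is 60000 nM (expected range 20000 nM to 150000 nM).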

Compound 3, half-maximal inhibitory concentration: 26400 nM
The estimate for compound 3 lay 2.3-fold (0.36 log units) above the measured number, and the stated range covers the measured number.
By their numbers in this assay, from the lowest: compounds 3, 2 and 1 (each within the scatter of the next).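

In this assay, for the compounds shown here, the carboxylic acid is the first free carboxy group seen at this position, and exchanging the methyl of the ester for hydrogen gives a 1.6-fold lower number from compound 1 to compound 3 (0.20 log units; within the scatter) on the same small side chain, so this single change leaves the reading level. The wider exchange on the amide-type nitrogen, 1-carboxyethyl in place of 1-(methoxycarbonyl)-2-methylbutyl, gives a 1.5-fold lower number from compound 2 to compound 3 (0.17 log units; within the scatter) and likewise does not separate the compounds, so all three now stand level whether the group on that nitrogen is an ester or an acid. No measurement is available that bears on what lies behind these readings.

On these data alone, whether a primary amide, an amine or a longer chain ending in a carboxylic acid on this nitrogen would move the reading beyond the scatter remains open. Also open, as far as these compounds go, are how a carboxylic acid carrying the sec-butyl side chain would read and whether a change in the shared core, rather than in this side chain, would separate the compounds in this assay at all.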